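Pyridin-3-yl in Place of 4-Fluorophenyl: An Expectation

The source may report more compounds than this note shows. Statements on the series, on what has been measured and on what is new or still open speak of the compounds shown alone.

Of the compounds shown here, two have numbers so far. Compound 1 `O=C([C@@H]1C[C@H](N2CCN(c3nccn3-c3ccccc3)CC2)CN1)N1CCSC1` gives 0.19 nM in an assay on a cell-free system (plasma) for inhibition of Dipeptidyl peptidase 4 (Rattus norvegicus), read by fluorescence, with a stated time of 60 min; on this read-out lower numbers stand for stronger inhibition and higher numbers for weaker inhibition. Compound 2 `Cc1cc(N2CCN([C@@H]3CN[C@H](C(=O)N4CCSC4)C3)CC2)n(-c2ccc(F)cc2)n1` gives 2.3 nM in this assay, the higher of the two numbers; the gap to compound 1 lies beyond the usual scatter of repeated measurements, so compound 2 is the weaker inhibitor of the pair. Compound 3 `Cc1cc(N2CCN([C@@H]3CN[C@H](C(=O)N4CCSC4)C3)CC2)n(-c2cccnc2)n1` has not been measured. It differs from compound 2 in one place: pyridin-3-yl in place of 4-fluorophenyl on an aromatic nitrogen. For the measured compounds named here, no pair of measured compounds shows the effect of this kind of change, so there is no measured step to lean on. Exchanging one six-membered aromatic ring for another that differs by a single hetero atom is expected to move the number little, in no clear direction, and not beyond the scatter. Compound 3 is therefore expected to give 2.5 nM in this assay, within 1 nM to 6 nM, which means an expected step of a 1.1-fold higher number from compound 2 to compound 3 (0.04 log units; within the scatter).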

Compound 3, half-maximal inhibitory concentration: 0.77 nM
Estimate against measurement, compound 3: 3.2-fold (0.51 log units) above; the whole stated range lies above it.
By their numbers in this assay, from the lowest: compound 1; then compound 3; then compound 2.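

On the aromatic nitrogen of the five-membered ring, pyridin-3-yl in place of 4-fluorophenyl gives a 3.0-fold lower number from compound 2 to compound 3 (0.48 log units; beyond the scatter) in this assay. For the compounds shown here, this is the first measured sign that the choice of six-membered aromatic ring at this place can move the number beyond the scatter, and here the step runs towards stronger inhibition. The change removes the fluorine and brings in a ring nitrogen with its hydrogen-bond acceptor, and no measurement shown ties the step to either part or explains it.

The compounds shown leave open whether the gain follows the ring nitrogen itself or the loss of the fluorine. Pyridin-4-yl, with the ring nitrogen placed differently, or 4-methoxyphenyl, which keeps a ring of carbon only, would each test a different side of that question.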